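The compounds below may be only part of what the source reports. "The series", "measured", "known", "first", "only" and "open" are said of these compounds alone.

Compound 1, `CC(=O)Nc1ccc(S(=O)(=O)NNC(=O)c2cccnc2Nc2ccc(Cl)cc2)cc1`, is one of two compounds with a result so far, and in a functional assay on 786-0 cells (Homo sapiens) for antiproliferative activity (on this read-out lower numbers stand for higher toxicity in this test and higher numbers for lower toxicity in this test), compound 1 gives > 100000 nM, which is a limit of the assay and not a number. Compound 2, `O=C(NNS(=O)(=O)c1ccc(F)cc1)c1cccnc1Nc1ccc(Cl)cc1Cl`, in this assay gives > 100000 nM, likewise a limit rather than a number. Among the measured compounds shown here, compound 1 therefore stands at the limit of > 100000 nM in this assay, at which 2 of the 2 values shown sit, so neither of the two results fixes a place on the scale, and no step between measured compounds can be reckoned from them.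

Compound 3, `O=C(NNS(=O)(=O)c1ccc(Cl)cc1Cl)c1cccnc1Nc1ccc(Cl)cc1`, has not been measured in this assay. It differs from compound 1 in a single place: 2,4-dichlorophenyl in place of 4-acetamidophenyl on a sulfonyl sulfur. For the measured compounds named here, with no measured step to lean on, the step from compound 1 to compound 3 is expected to be a number no higher from compound 1 to compound 3 (the limit leaves the size open), that is, none beyond the scatter, since compound 1 sits at the limit of > 100000 nM in this assay, at which 2 of the 2 values shown sit. For compound 3 in this assay the estimate is 100000 nM, within a range from 30000 nM to 300000 nM, with a substantial chance that only a limit is reported again.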

Compound 3, concentration lethal to 50% of the cells: > 100000 nM
Compound 3 was reported as a limit; the forecaster's own chance of this, stated with the estimate: 75%; the middle value lies on the limit itself.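

Among the compounds shown here, compound 1 and compound 3 both stand at a limit in this assay, not at a number, so no step from one to the other can be read: the limit of > 100000 nM in this assay, at which 3 of the 3 values shown sit.

The compounds shown leave open whether any group on the sulfonyl sulfur can bring a result in this assay onto the scale at all, and none of them yet gives a number there.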